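Fluoro for Chloro on the Aromatic Ring

A few compounds are considered here, and "the series" means these few. Any claim that something is new, unique, unknown or untested is made for them only; others in the source may bear on it.

Measured compounds:
- compound 1, `Clc1ccc(OCC2=NCCO2)cc1`: 30%
- compound 2, `Clc1ccccc1OCC1=NCCO1`: 20%
- compound 3, `Cc1cc(OCC2=NCCO2)ccc1Cl`: 50%

In a toxicity assay on the whole organism with Rattus norvegicus as the target, at a dose of 100 mg/kg by the oral route (a lower number here means a weaker effect, a higher number a stronger effect of the compound at the dose given), compound 1 gives 30%, the second highest of the three numbers. Its nearest neighbour is compound 2, whose value in this assay is 20%, within the scatter of compound 1; the furthest is compound 3 with 50% in this assay. Among the compounds with values here, the one step recorded among the measured compounds, a number 20 percentage points higher from compound 1 to compound 3 (beyond the scatter), arises from methyl in place of hydrogen on an aromatic carbon and is modest.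

Compound 4, `Fc1ccc(OCC2=NCCO2)cc1`, has not yet been measured. Its difference from compound 1 is fluoro in place of chloro on an aromatic carbon. Within the data shown here, no measured step involves an exchange of one halogen for another, so none bears directly on this change; the only recorded step concerns a different substitution. With nothing to suggest a shift beyond the scatter, compound 4 is expected to lie close to compound 1, the estimated step being a number 5 percentage points lower from compound 1 to compound 4 (within the scatter). The estimate for compound 4 in this assay is therefore 25%, with a range from 10% to 45%.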

Compound 4, a percentage reported as activity, at one dose (the size of the read-out at that dose, not a potency): 25%
Beside the measured number, compound 4's estimate shows no gap at the digits printed; the measured number falls inside the stated range.
By their numbers in this assay, from the lowest: compounds 2, 4 and 1 (each within the scatter of the next); then compound 3.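

At this position, on an aromatic carbon para to a group of 7 heavy atoms, fluoro in place of chloro gives a number 5 percentage points lower from compound 1 to compound 4 (within the scatter) in this assay, so the chloro of compound 1 can give way to this smaller halogen without a shift beyond the scatter. The earlier compounds shown here showed only what a methyl group added elsewhere on the ring does, and nothing about changing the group at this position itself. No supporting evidence is available to explain this result.

As far as these compounds go, what remains open is whether a group of another kind at this position, such as methoxy, an amine or a carboxylic acid, would move the number beyond the scatter. From the compounds shown here alone, it is also open whether the same exchange of fluoro for chloro would stay within the scatter in compound 2 or compound 3.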